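Swapping an ester chain for a hydroxyethyl group

The source may hold more compounds than are shown below. What is called first, only, known or untested is meant among the compounds shown, and "the series" means these compounds.

Two ureas sharing one core have been measured in an assay on isolated protein for inhibition of ATP-dependent RNA helicase DDX3X (Homo sapiens), read by FRET, with stated times of 30 s and 40 min; on this read-out higher numbers stand for weaker inhibition and lower numbers for stronger inhibition. Compound 1, `Cc1ccccc1NC(=O)Nc1ccc(-n2cc(CCO)nn2)cc1`, gives 13000 nM. Compound 2, `CCOC(=O)CCc1cn(-c2ccc(NC(=O)Nc3ccccc3C(F)(F)F)cc2)nn1`, gives 2020 nM, the lower of the two numbers, and its gap to compound 1 lies beyond the usual scatter, so compound 2 is the stronger inhibitor of the pair. Compound 3, `O=C(Nc1ccc(-n2cc(CCO)nn2)cc1)Nc1ccccc1C(F)(F)F`, keeps the trifluoromethyl-bearing side of compound 2 but changes the chain on the triazole: hydroxy in place of ethoxycarbonyl on a saturated chain carbon, two bonds along the chain from an aromatic carbon. For the measured compounds named here, no measured pair isolates this particular change, because compound 1 differs from compound 2 in two places at once. Going by the values given here, the expectation is a modest loss of inhibition, estimated as the step of a 2.0-fold higher number from compound 2 to compound 3 (0.30 log units; within the scatter), since the only compound carrying the hydroxyethyl chain, compound 1, gave the weaker 13000 nM. Compound 3 is therefore expected to show about 4000 nM, with a likely range from 1500 nM to 12000 nM.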

Compound 3, half-maximal inhibitory concentration: 11200 nM
The estimate for compound 3 lay 2.8-fold (0.45 log units) below the measured number; low and high end bracket the measured number.
By their numbers in this assay, from the lowest: compound 2; then compounds 3 and 1 (each within the scatter of the next).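

In this assay, for the compounds shown here, hydroxy in place of ethoxycarbonyl on the chain gives a 5.5-fold higher number from compound 2 to compound 3 (0.74 log units; beyond the scatter) and is the first single change at this position that can be read, showing that what the chain carries here changes the number beyond the scatter. With the 2-hydroxyethyl chain kept, trifluoromethyl in place of methyl on an aromatic carbon gives a 1.2-fold lower number from compound 1 to compound 3 (0.06 log units; within the scatter) and so cannot be told apart from the scatter on this chain. Nothing measured here explains either step.

As far as these compounds go, it remains open whether the step depends on the whole ester or only on part of it, a question that the carboxylic acid, a primary amide or a longer chain at this position could help answer. Also open, from the compounds shown here alone, is whether methyl and trifluoromethyl stand as close together on the 2-(ethoxycarbonyl)ethyl chain as they do on the 2-hydroxyethyl chain.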